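This account rests on a few compounds, and the source may have more. Where it says the series, first, only, none or still open, it means among the compounds named here.

Compound 2 `COc1nc(N)nc2c1c(-c1cccs1)cn2[C@@H]1O[C@H](CO)[C@@H](O)[C@H]1O` carries a thiophen-2-yl group. In an ADME assay on MRC5 cells (Homo sapiens), read by MTT assay, with a stated time of 72 h (on this read-out higher numbers stand for weaker inhibition and lower numbers for stronger inhibition), compound 2 gives > 100000 nM, a limit of the assay rather than a number. Compound 1 `COc1nc(N)nc2c1c(-c1ccsc1)cn2[C@@H]1O[C@H](CO)[C@@H](O)[C@H]1O` differs from it by thiophen-3-yl in place of thiophen-2-yl on an aromatic carbon. In this assay compound 1 also gives only the limit > 100000 nM. The step that the two limits leave unreadable from compound 2 to compound 1 cannot be sized, since (the limit of > 100000 nM in this assay, at which 3 of the 3 values shown sit). Compound 3 `CNc1ncnc2c1c(-c1cccs1)cn2[C@@H]1O[C@H](CO)[C@@H](O)[C@H]1O` has another core; how it differs from the core of compound 2 is not broken down here. In this assay compound 3 gives > 100000 nM, again a limit. Compound 4 `CNc1ncnc2c1c(-c1ccsc1)cn2[C@@H]1O[C@H](CO)[C@@H](O)[C@H]1O` is not yet measured and differs from compound 3 by thiophen-3-yl in place of thiophen-2-yl on an aromatic carbon, the same change as between compound 2 and compound 1. Because the limit of > 100000 nM in this assay, at which 3 of the 3 values shown sit, holds for every value shown, the step from compound 3 to compound 4 is expected to be a step that the limit leaves unreadable from compound 3 to compound 4. Compound 4 is expected to give about 150000 nM, most likely again only as a limit, within 50000 nM to 600000 nM.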

Compound 4, half-maximal inhibitory concentration: > 100000 nM
Compound 4: only a limit was reported (the forecaster's own chance of this, stated with the estimate: 90%); the middle value is on the limit's open side.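

Compound 3 and compound 4 both stand only as limits, so the step between them cannot be read, for this reason: (the limit of > 100000 nM in this assay, at which 4 of the 4 values shown sit). The compounds shown leave open how strongly any of them inhibits in this assay and whether thiophen-3-yl and thiophen-2-yl differ at all.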